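Solubility notes: replacing the 4-(pyridin-2-yl)piperazin-1-yl group

The source may hold more compounds than are shown below. What is called first, only, known or untested is meant among the compounds shown, and "the series" means these compounds.

Measured in a physicochemical assay for solubility, read by spectrophotometry, in phosphate buffer, with a stated time of 2 h, at pH 7.4; a higher number here means a more soluble compound, a lower number a less soluble compound:
Compound 1 `COc1ccc2[nH]c(C(=O)N3CC(=O)N(Cc4ccccc4)[C@@H](CCN4CCC5(CC4)CC5)C3)cc2c1`: > 25000 nM (a limit, not a number)
Compound 2 `COc1ccc2[nH]c(C(=O)N3CC(=O)N(Cc4ccccc4)[C@@H](CN4CCN(c5ccccn5)CC4)C3)cc2c1`: 30200 nM

Going by the values given here, compound 2, at 30200 nM, holds the only actual number in this short series. The entry for compound 1 is the limit of > 25000 nM in this assay, at which 1 of the 2 values shown sits, and it is only a limit. Compound 3 `COc1ccc2[nH]c(C(=O)N3CC(=O)N(Cc4ccccc4)[C@@H](CN4CC5(CCC5)C4)C3)cc2c1` keeps the shared core and differs from compound 2 in one group, on a saturated chain carbon bound to a saturated ring carbon: a group of 7 heavy atoms (6 carbon, 1 nitrogen; one four-membered non-aromatic ring of carbon only, one four-membered non-aromatic ring with 1 hetero atom) in place of a group of 12 heavy atoms (9 carbon, 3 nitrogen; one six-membered non-aromatic ring with 2 hetero atoms, one six-membered aromatic ring with 1 hetero atom), on a saturated chain carbon bound to a saturated ring carbon. Among the compounds with values here, the one measured step, a step that the limit leaves unreadable from compound 1 to compound 2, changes a group at the same place but gives no usable size. The expectation therefore rests on compound 2 at 30200 nM, with no step beyond the scatter and no direction expected in this assay. The expected change is a 1.0-fold lower number from compound 2 to compound 3 (0.00 log units; within the scatter). For compound 3 the estimate is 30000 nM, with an expected range of 14000 nM to 60000 nM.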

Compound 3, solubility: 60700 nM
Compound 3: middle estimate off by 2.0-fold (0.31 log units), on the low side; the whole stated range lies below it.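

At this place, on a saturated chain carbon bound to a saturated ring carbon, the series now has its first readable step (a 2.0-fold higher number from compound 2 to compound 3 (0.30 log units; within the scatter)), with a group of 7 heavy atoms in place of the 4-(pyridin-2-yl)piperazin-1-yl group. In this assay the two groups are not told apart, even though the entering group carries no six-membered aromatic ring with 1 hetero atom. Compound 1 remains a limit and not a number, and the steps to and from it cannot be read: the limit of > 25000 nM in this assay, at which 1 of the 3 values shown sits.

Left open is whether a different kind of group at this place, such as a carboxylic acid or an open-chain amine, would give a step beyond the scatter. With a single readable step, no direction can be stated for this place.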